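Quinolin-3-yl on the Amide Nitrogen of Compound 2

This account rests on a few compounds, and the source may have more. Where it says the series, first, only, none or still open, it means among the compounds named here.

In an in vivo ADME assay on the whole organism for pharmacokinetics, with Rattus norvegicus as the target, at a dose of 2 mg/kg by the oral route (on this read-out lower numbers stand for lower exposure and higher numbers for higher exposure at the dose given), compound 2 (`CN(C)CCCOc1cc(C(=O)Nc2ccc(Br)cc2)n(Cc2ccccc2)n1`) gives 26.5 nM and holds the higher of the two numbers, while compound 1 (`COc1ccc(NC(=O)c2cc(OCCCN(C)C)nn2Cc2ccccc2)cc1Cl`) gives 12.2 nM on the lower side. Compound 3 (`CN(C)CCCOc1cc(C(=O)Nc2cnc3ccccc3c2)n(Cc2ccccc2)n1`) carries quinolin-3-yl in place of 4-bromophenyl on an amide-type nitrogen. Within the data shown here, the only measured step at that place (a 2.2-fold higher number from compound 1 to compound 2 (0.34 log units; beyond the scatter)) is modest, and it involves no quinolin-3-yl group, so it sets a size but no clear direction. A small expected step (a 1.3-fold lower number from compound 2 to compound 3 (0.12 log units; within the scatter)) is therefore taken, with no change beyond the scatter expected. Compound 3 is estimated at 20 nM (expected range 7 nM to 60 nM).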

Compound 3, maximal plasma concentration: 33.3 nM
Compound 3: middle estimate off by 1.7-fold (0.22 log units), on the low side; measured number inside the range.
By their numbers in this assay, from the lowest: compound 1; then compounds 2 and 3 (each within the scatter of the next).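

In this assay, quinolin-3-yl in place of 4-bromophenyl gives a 1.3-fold higher number from compound 2 to compound 3 (0.10 log units; within the scatter), so this amide-type nitrogen accepts a group of 10 heavy atoms, one of them a ring nitrogen, with no change beyond the scatter. Set against 3-chloro-4-methoxyphenyl, the same group gives a 2.7-fold higher number from compound 1 to compound 3 (0.44 log units; beyond the scatter), which puts compound 3 with compound 2 clear of compound 1. Nothing at hand explains these numbers. Still open, from the compounds shown here alone, is whether a simple alkyl chain at this nitrogen, or an amine or carboxylic acid on its ring, would keep them.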